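The source may hold more compounds than are shown below. What is called first, only, known or untested is meant among the compounds shown, and "the series" means these compounds.

In a functional assay on HepG2 cells (Homo sapiens) for cytotoxicity, read by MTT assay (a lower number here means a stronger inhibitor, a higher number a weaker inhibitor), compound 1 `C#CCOc1cc(/C=C/C(=O)c2ccc(OC)c3c2OC(C)(C)C=C3)ccc1OC` reads > 10000 nM, which is a limit of the assay. Compound 2 `COc1ccc(/C=C/C(=O)c2ccc(OC)c3c2OC(C)(C)C=C3)cc1OC(=O)C(C)C` gives 250 nM. Going by the values given here, compound 3 `C=CC(=O)Oc1cc(/C=C/C(=O)c2ccc(OC)c3c2OC(C)(C)C=C3)ccc1OC` gives 160 nM, and its only numeric neighbour is compound 2. Replacing propargyl on the oxygen gives an at least 40-fold lower number from compound 1 to compound 2 (1.60 log units; beyond the scatter) and an at least 62-fold lower number from compound 1 to compound 3 (1.79 log units; beyond the scatter), while exchanging isopropyl for vinyl on the carbonyl carbon gives only a 1.6-fold lower number from compound 2 to compound 3 (0.19 log units; within the scatter). Compound 4 `COc1ccc(/C=C/C(=O)c2ccc(OC)c3c2OC(C)(C)C=C3)cc1OC(=O)C1CC1` carries cyclopropyl in place of vinyl on a carbonyl carbon, with cyclopropyl in place of vinyl on a carbonyl carbon. Among the compounds with values here, the nearest precedent is a 1.6-fold lower number from compound 2 to compound 3 (0.19 log units; within the scatter), so no step beyond the scatter is expected in this assay. The estimated change is a 1.3-fold higher number from compound 3 to compound 4 (0.10 log units; within the scatter). For compound 4 the estimated value is 200 nM, with an expected range of 80 nM to 500 nM.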

Compound 4, half-maximal inhibitory concentration: 220 nM
Estimate against measurement, compound 4: 1.1-fold (0.04 log units) below; low and high end bracket the measured number.
By their numbers in this assay, from the lowest: compounds 3, 4 and 2 (each within the scatter of the next). At a limit, above all of these: compound 1.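

A ring on the carbonyl carbon leaves no readable change in this assay: a 1.4-fold higher number from compound 3 to compound 4 (0.14 log units; within the scatter) and a 1.1-fold lower number from compound 2 to compound 4 (0.06 log units; within the scatter). Vinyl, isopropyl and cyclopropyl are therefore not told apart at this position, with or without a ring or a double bond. The step from propargyl on the oxygen, an at least 45-fold lower number from compound 1 to compound 4 (1.65 log units; beyond the scatter), starts from a limit and gives only a bound: the limit of > 10000 nM in this assay, at which 1 of the 4 values shown sits.

Open, from the compounds shown here alone, is whether a longer chain or an amine on the carbonyl carbon stays in this range. Also open, going by these compounds, is how a free hydroxyl on that oxygen would read.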